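The source may hold more compounds than are shown below. What is called first, only, known or untested is meant among the compounds shown, and "the series" means these compounds.

Series notes. In an assay on cells for inhibition of HSP60/HSP10 (Homo sapiens), with a stated time of 60 min (a lower number here means a stronger inhibitor, a higher number a weaker inhibitor), compound 3 `O=S(=O)(Nc1ccc(-c2nc3ccccc3o2)cc1)c1ccc(F)cc1` gives 73000 nM. Compound 1 `O=S(=O)(Nc1ccc(-c2nc3ccccc3o2)cc1)c1cccs1` gives 63000 nM; the step of a 1.2-fold higher number from compound 1 to compound 3 (0.06 log units; within the scatter) leaves compound 3 with the higher of the two numbers, within the scatter. Compound 2 `COc1ccc(S(=O)(=O)Nc2ccc(-c3nc4ccccc4o3)cc2)cc1` gives > 100000 nM, a limit of the assay and not a number; (the limit of > 100000 nM in this assay, at which 1 of the 3 values shown sits). Compound 4 `O=S(=O)(Nc1ccc(-c2nc3cc(NS(=O)(=O)c4ccc(F)cc4)ccc3o2)cc1)c1ccc(F)cc1` carries ((4-fluorophenyl)sulfonyl)amino in place of hydrogen on an aromatic carbon. The measured steps, an at least 1.5-fold higher number from compound 1 to compound 2 (0.20 log units; that floor lies within the scatter) and an at least 1.3-fold lower number from compound 2 to compound 3 (0.13 log units; that floor lies within the scatter) together with the step already given, all exchange the aryl group on the sulfonyl sulfur; none adds a second ((4-fluorophenyl)sulfonyl)amino group to the shared core, so none bears directly on this change, and no direction can be read from them. The step of a 1.0-fold lower number from compound 3 to compound 4 (0.02 log units; within the scatter) in this assay is therefore expected to stay within the scatter, with wide uncertainty. Compound 4 is estimated at 70000 nM, range 20000 nM to 200000 nM.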

Compound 4, half-maximal inhibitory concentration: 67000 nM
Estimate against measurement, compound 4: 1.0-fold (0.02 log units) above; the measured number falls inside the stated range.
By their numbers in this assay, from the lowest: compounds 1, 4 and 3 (each within the scatter of the next). At a limit, above all of these: compound 2.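

The step of a 1.1-fold lower number from compound 3 to compound 4 (0.04 log units; within the scatter) is the first shown in this assay that alters the shared core rather than the aryl group on the sulfonyl sulfur. At this aromatic carbon, a ((4-fluorophenyl)sulfonyl)amino group, with its 11 heavy atoms, can replace hydrogen without moving the number beyond the scatter. Nothing measured here bears on why this step stays so small.

As far as these compounds go, whether an amine or a carboxylic acid at this carbon would give a step beyond the scatter remains open. Also open, from the compounds shown here alone, is whether the same holds at other carbons of the shared core.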